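The compounds below may be only part of what the source reports. "The series", "measured", "known", "first", "only" and "open" are said of these compounds alone.

Measured so far:
- compound 1 `COC(=O)C(C)(C)c1nc(-c2ccc(OC)cc2)c(-c2ccc(OC)cc2)s1`: 100%
- compound 2 `COc1ccc(-c2nc(C(C)C)sc2-c2ccc(OC)cc2)cc1`: 85%

In a functional assay on the whole organism for inhibition, with Cavia porcellus as the target, at a dose of 5 mg/kg by the oral route (on this read-out lower numbers stand for a weaker effect and higher numbers for a stronger effect at the one dose given), compound 2 gives the lower of the two numbers, its nearest neighbour being compound 1 at 100%. For the measured compounds named here, the single measured step, a number 15 percentage points lower from compound 1 to compound 2 (beyond the scatter), is the only one that bears on the next change. Compound 3 `COc1ccc(-c2nc(CC(N)=O)sc2-c2ccc(OC)cc2)cc1` differs from compound 2 as follows: carbamoylmethyl in place of isopropyl on an aromatic carbon. A carbonyl-bearing group is thus brought back onto the shared core, and a step of similar size in the opposite direction is therefore expected, although this rests on one comparison only. The expected step is a number 5 percentage points higher from compound 2 to compound 3 (within the scatter). Compound 3 is estimated at 90%, within a range from 65% to 100%.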

Compound 3, a percentage reported as inhibition, in the whole organism at one dose (the size of the read-out at that dose, not a potency): 96%
Beside the measured number, compound 3's estimate is 6 percentage points below it; the range from low to high includes it.
By their numbers in this assay, from the lowest: compound 2; then compounds 3 and 1 (each within the scatter of the next).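

At the aromatic carbon next to the ring nitrogen and the ring sulfur, this assay separates the two replacements of isopropyl from it: a number 11 percentage points higher from compound 2 to compound 3 (beyond the scatter), and the gain is of modest size. Carbamoylmethyl and 1-(methoxycarbonyl)-1-methylethyl are not told apart, with a number 4 percentage points lower from compound 1 to compound 3 (within the scatter), so among these three compounds both carbonyl-bearing groups read alike and only isopropyl stands apart. No supporting data explain this difference.

As far as these compounds go, whether a carboxylic acid, an amine or a longer chain ending in the amide would hold the effect at this position remains open. A single dose also shows only a stronger or weaker effect at that dose.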